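Methoxy in place of chloro: what inhibition to expect

This account rests on a few compounds, and the source may have more. Where it says the series, first, only, none or still open, it means among the compounds named here.

Within the data shown here, in a functional assay on MV4-11 cells (Homo sapiens) for inhibition, with a stated time of 120 h, tested at 10 uM (a higher number here means more inhibition at the concentration tested (going by the name of the read-out), a lower number less inhibition), compound 2 `Cc1n[nH]c2ccc(-c3nc4cnc(N5CCN(C)CC5)cn4c3Nc3ccc(Cl)cc3)cc12` gives 83.7%, the highest of the three numbers measured so far. Compound 1 `Cc1n[nH]c2ccc(-c3nc4cnc(N5CCN(C)CC5)cn4c3Nc3ccc(F)cc3)cc12` gives 0%, and compound 3 `Cc1n[nH]c2ccc(-c3nc4cnc(N5CCC(C)CC5)cn4c3Nc3ccc(Cl)cc3)cc12` gives 28%. The step of a number 83.7 percentage points higher from compound 1 to compound 2 (beyond the scatter) shows how strongly the group on the (4-chlorophenyl)amino part governs the read-out, and the step of a number 55.7 percentage points lower from compound 2 to compound 3 (beyond the scatter) shows a similarly large effect at the other end of the shared core. Compound 4 `COc1ccc(Nc2c(-c3ccc4[nH]nc(C)c4c3)nc3cnc(N4CCN(C)CC4)cn23)cc1` differs from compound 2 by methoxy in place of chloro on an aromatic carbon. Among the measured compounds shown here, the only measured step at this place is a number 83.7 percentage points higher from compound 1 to compound 2 (beyond the scatter); no measured compound carries a methoxy there, so the direction for compound 4 cannot be fixed from the data with confidence. Because compound 1 gives 0% with fluoro at the same place, a move away from chloro is taken to carry a real risk of a large loss, though the step from chloro to methoxy need not behave like the step from fluoro to chloro. The expected step is a number 43.7 percentage points lower from compound 2 to compound 4 (beyond the scatter). Compound 4 is therefore estimated at 40%, within a range from 5% to 85%.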

Compound 4, a percentage reported as inhibition, at one concentration (the size of the read-out at that concentration, not a potency): 3.32%
Beside the measured number, compound 4's estimate is 36.7 percentage points above it; measured number below the stated range.
By their numbers in this assay, from the lowest: compounds 1 and 4 (each within the scatter of the next); then compound 3; then compound 2.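

In this assay the change to methoxy gives a number 80.4 percentage points lower from compound 2 to compound 4 (beyond the scatter) and so the sharp dependence on the group at this place is not a matter of fluoro alone. Methoxy set against fluoro gives a number 3.3 percentage points higher from compound 1 to compound 4 (within the scatter) and thus, of the three groups compared on this aromatic carbon with the 4-methylpiperazin-1-yl group kept, only chloro goes with a high number. No measurement shown here explains why chloro stands apart from the other two groups.

As far as these compounds go, whether chloro is singular remains open, since bromo, methyl or trifluoromethyl at the same place could either keep the inhibition or lose it. Also open, from the compounds shown here alone, is whether methoxy would give the same result on the 4-methylpiperidin-1-yl compound, compound 3.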